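The source may hold more compounds than are shown below. What is called first, only, known or untested is meant among the compounds shown, and "the series" means these compounds.

Measured compounds:
compound 1 `FC(F)(F)c1ccc2nc(-c3cccc(-c4nc5ccc(C(F)(F)F)cc5[nH]4)c3)[nH]c2c1` gives 10900 nM in an ADME assay on L02 cells (Homo sapiens) for cytotoxicity, read by MTT assay, with a stated time of 48 h; a lower number here means a stronger inhibitor, a higher number a weaker inhibitor
compound 2 `COc1cc(-c2nc3ccc(C(F)(F)F)cc3[nH]2)cc(-c2nc3ccc(C(F)(F)F)cc3[nH]2)c1` gives 10100 nM in this assay

For the measured compounds named here, compound 2 and compound 1 stand close together on this assay: the only measured step, a 1.1-fold lower number from compound 1 to compound 2 (0.03 log units; within the scatter), is too small to count as a real difference, so the two numbers are best read as one value. Compound 3 `O=[N+]([O-])c1cc(-c2nc3ccc(C(F)(F)F)cc3[nH]2)cc(-c2nc3ccc(C(F)(F)F)cc3[nH]2)c1` differs from compound 2 by a single change, (nitro in place of methoxy on an aromatic carbon). Going by the values given here, no measured step involves a nitro group, and the one step that is known, a 1.1-fold lower number from compound 1 to compound 2 (0.03 log units; within the scatter), concerns a different change and stayed within the scatter. There is therefore no evidence that swapping the group at this position moves this assay, and the expectation is a step of a 1.0-fold lower number from compound 2 to compound 3 (0.00 log units; within the scatter) that does not go beyond the scatter. Compound 3 is thus estimated at 10000 nM, with a range from 4000 nM to 25000 nM.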

Compound 3, half-maximal inhibitory concentration: 3700 nM
Compound 3: middle estimate off by 2.7-fold (0.43 log units), on the high side; measured number below the stated range.
By their numbers in this assay, from the lowest: compound 3; then compounds 2 and 1 (each within the scatter of the next).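

The group on this aromatic carbon, meta to two large groups, can shift the number in this assay: nitro in place of methoxy gives a 2.7-fold lower number from compound 2 to compound 3 (0.44 log units; beyond the scatter) and nitro in place of hydrogen gives a 2.9-fold lower number from compound 1 to compound 3 (0.47 log units; beyond the scatter). Hydrogen and methoxy had given values within the scatter of each other, so nitro is the first group shown here to move the result beyond the scatter, though only modestly. No supporting measurement shows why nitro behaves differently from the other two groups.

For the compounds shown here, with only three groups at this position, it remains open whether the shift is particular to nitro or would also appear with an amine, a nitrile or a carboxylic acid. On these data alone, it is also open whether the step would keep its size if the two trifluoromethyl groups gave way to chlorine atoms.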